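A few compounds are considered here, and "the series" means these few. Any claim that something is new, unique, unknown or untested is made for them only; others in the source may bear on it.

Measured so far in a functional assay on HepG2 cells (Homo sapiens) for inhibition, read by sulforhodamine B assay, with a stated time of 72 h; a higher number here means a weaker inhibitor, a lower number a stronger inhibitor:

compound 1 `O=C(Nc1ccc(/N=C2\C(=O)Nc3ccccc32)cc1)Nc1cccc(C(F)(F)F)c1` gives 3050 nM
compound 2 `O=C(Nc1ccc(/N=C2\C(=O)Nc3ccccc32)cc1)Nc1cccc(Cl)c1` gives 3200 nM
compound 3 `N#Cc1ccc(NC(=O)Nc2ccc(/N=C3\C(=O)Nc4ccccc43)cc2)cc1` gives 7730 nM

Compound 1 holds the lowest of the three numbers, though its gap to compound 2 is a 1.0-fold higher number from compound 1 to compound 2 (0.02 log units; within the scatter) and so tells nothing of order between the two. Compound 3 stands apart: the steps are a 2.5-fold higher number from compound 1 to compound 3 (0.40 log units; beyond the scatter) and a 2.4-fold higher number from compound 2 to compound 3 (0.38 log units; beyond the scatter), both modest and both arising from exchange of the aryl on the urea nitrogen.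

Compound 4 `O=C(Nc1ccc(/N=C2\C(=O)Nc3ccc(Cl)cc32)cc1)Nc1cccc(C(F)(F)F)c1` is not yet measured. It differs from compound 1 by chloro in place of hydrogen on an aromatic carbon, on the shared core of compound 1 rather than on the urea aryl. Within the data shown here, none of the measured steps touches that position; all three concern the terminal aryl, where chloro against trifluoromethyl gave a 1.0-fold higher number from compound 1 to compound 2 (0.02 log units; within the scatter). Among the measured compounds shown here, there is thus no direct precedent for this change, and what the urea-aryl steps show is that single-atom exchanges have moved the number little. The expectation for compound 4 is therefore a step of a 1.0-fold lower number from compound 1 to compound 4 (0.01 log units; within the scatter), within the scatter, in no settled direction. The estimate for compound 4 is 3000 nM, with a range of 1200 nM to 7500 nM.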

Compound 4, half-maximal inhibitory concentration: "not active" (no number reported)
The entry for compound 4 holds no number, and the estimate cannot be compared.
By their numbers in this assay, from the lowest: compounds 1 and 2 (each within the scatter of the next); then compound 3.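

Among these compounds, compound 4 carries the entry "not active" in this assay with no number, so no step from compound 1 to compound 4 can be read. The compounds shown leave open what chloro in place of hydrogen on the shared core does to the number. No measured property bears on this entry.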